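From Methoxy to Acetyl on an Aromatic Ring

The compounds below may be only part of what the source reports. "The series", "measured", "known", "first", "only" and "open" are said of these compounds alone.

Of the compounds shown here, three have been measured so far in a functional assay on A549 cells (Homo sapiens) for cytotoxicity, read by MTT assay, with a stated time of 48 h (a higher number here means a weaker inhibitor, a lower number a stronger inhibitor), and the lowest number belongs to compound 3. Compound 1 `C=C1CCC[C@]2(C)CCC(C=O)=CC[C@@]12C` gives 145000 nM and compound 2 `C#CC1=CC[C@]2(CC1)C(=C)CC[C@H]2C(C)C` gives 103000 nM on that scale. Compound 3 `C=C1CCC[C@]2(C)CCC(c3cn(-c4ccc(OC)cc4)nn3)=CC[C@@]12C` gives 34700 nM and is the strongest of the three, with gaps to both others that lie beyond the usual scatter of repeated measurements.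

Compound 4 `C=C1CCC[C@]2(C)CCC(c3cn(-c4ccc(C(C)=O)cc4)nn3)=CC[C@@]12C` keeps the whole of compound 3 except for one group. It has acetyl in place of methoxy on an aromatic carbon, para to a large group (acetyl in place of methoxy on an aromatic carbon), so 4-methoxyphenyl becomes 4-acetylphenyl. For the measured compounds named here, no two measured compounds here differ by a swap of this kind, so the numbers offer no direct guide to its effect. Going by the values given here, since the shared core stays and only this one group changes, the safest expectation in this assay is that compound 4 lands close to compound 3 at 34700 nM and shows no step beyond the scatter. The estimated change is a 1.2-fold higher number from compound 3 to compound 4 (0.06 log units; within the scatter) and would sit within that scatter. For compound 4 the expected value is 40000 nM with an estimated range from 17000 nM to 95000 nM in this measurement.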

Compound 4, half-maximal inhibitory concentration: 46400 nM
The estimate for compound 4 lay 1.2-fold (0.06 log units) below the measured number, and the stated range covers the measured number.
By their numbers in this assay, from the lowest: compounds 3 and 4 (each within the scatter of the next); then compounds 2 and 1 (each within the scatter of the next).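

For the compounds shown here, this is the first pair of measured compounds that differ in one place, so the effect of a single group on the aromatic ring can now be read directly. In this assay, acetyl in place of methoxy on an aromatic carbon, para to a large group, gives a 1.3-fold higher number from compound 3 to compound 4 (0.13 log units; within the scatter), so at this position the two groups cannot be told apart by this measurement, even though acetyl is the larger by heavy-atom count and brings a double bond outside aromatic rings. No measurement at hand offers an explanation for how closely the two compounds agree.

Methoxy and acetyl both carry no net charge and no hydrogen-bond donor, so it remains open whether an amine or a carboxylic acid at the same place would also stay within the scatter of compound 3. Also open, on these data alone, is whether a longer chain here, or a simple hydrogen with no group at all, would shift the number beyond the scatter, which would show whether this position matters in this assay.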